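Nitro in place of fluoro on a shared long-chain amide core

The compounds below may be only part of what the source reports. "The series", "measured", "known", "first", "only" and "open" are said of these compounds alone.

Compound 2 `CCCCCCCCCCCCCCCCCCNC(=O)[C@H]1CSC(c2ccc(F)cc2)N1` carries a fluoro group on an aromatic carbon of its core, and in a functional assay on TSU-Pr1 cells for antiproliferative activity against TSU (Homo sapiens), read by sulforhodamine B assay (a higher number here means a weaker inhibitor, a lower number a stronger inhibitor), compound 2 gives 5400 nM. Among the two measured compounds it shows the highest number; its only neighbour, compound 1 `CCCCCCCCCCCCCCCCCCNC(=O)[C@H]1CSC(c2ccc(N(C)C)cc2)N1`, carries a dimethylamino group at the same place, and in this assay compound 1 gives 3000 nM. The step of a 1.8-fold higher number from compound 1 to compound 2 (0.26 log units; within the scatter) separates them, and that difference falls within the scatter. Compound 3 `CCCCCCCCCCCCCCCCCCNC(=O)[C@H]1CSC(c2ccc([N+](=O)[O-])cc2)N1` is not yet measured; it differs from compound 2 in one place: nitro in place of fluoro on an aromatic carbon. Within the data shown here, no measured step covers nitro in place of fluoro. Among the measured compounds shown here, the one step available, a 1.8-fold higher number from compound 1 to compound 2 (0.26 log units; within the scatter), shows that exchanging one group for another at this aromatic carbon left the number within the scatter, so a step of no more than the scatter is expected from compound 2 to compound 3 in this assay, with no direction favoured. Compound 3 is therefore estimated at 5000 nM, with a range from 1500 nM to 16000 nM. This corresponds to an expected step of a 1.1-fold lower number from compound 2 to compound 3 (0.03 log units; within the scatter).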

Compound 3, half-maximal inhibitory concentration: 15900 nM
Compound 3: the middle estimate sits 3.2-fold (0.50 log units) below what was measured; low and high end bracket the measured number.
By their numbers in this assay, from the lowest: compounds 1 and 2 (each within the scatter of the next); then compound 3.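

In this assay, this aromatic carbon, para to a large group, no longer looks indifferent to what it carries: the change from 4-fluorophenyl to 4-nitrophenyl gives a 2.9-fold higher number from compound 2 to compound 3 (0.47 log units; beyond the scatter), a modest step but the first one here beyond the scatter. Set against dimethylamino, nitro gives a 5.3-fold higher number from compound 1 to compound 3 (0.72 log units; beyond the scatter), so compound 3 stands apart from compounds 1 and 2, which remain within the scatter of each other, and the choice of group at this carbon does change the number, though only modestly. Nothing given here accounts for nitro being the group that separates from the other two.

With only three groups seen at this carbon, the compounds shown leave open whether a primary amine, a carboxylic acid, a nitrile or a trifluoromethyl group would fall with compound 3 or with compounds 1 and 2. They also leave open whether the step from fluoro to nitro would keep its direction and size if a shorter chain replaced the long chain on the amide of the shared core.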